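The compounds below may be only part of what the source reports. "The series", "measured", "known", "first", "only" and "open" are said of these compounds alone.

In a functional assay on A498 cells (Homo sapiens) for inhibition, read by sulforhodamine B assay, with a stated time of 48 h, tested at 10 uM (on this read-out higher numbers stand for more inhibition of growth at the one concentration tested and lower numbers for less inhibition of growth), three compounds have been measured so far.

Compound 1 `COc1ccc(-c2nc3sc(-c4ccccc4)cn3n2)cc1` gives 56%
Compound 2 `COc1cc(-c2nc(N)n(CC(=O)Nc3ccc(/C(C)=N\O)cc3)n2)cc(OC)c1OC` gives 11.2%
Compound 3 `C/C(=N/O)c1ccc(NC(=O)Cn2nc(-c3ccccc3)nc2N)cc1` gives 19.6%

Compound 1 has the highest of these three numbers, and its gaps to both of the others lie beyond the usual scatter of repeated measurements. Compound 2 and compound 3 are built quite differently from compound 1, so their numbers offer little guidance here.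

Compound 4 `COc1ccc(-c2nc3sc(-c4ccc(Cl)cc4)cn3n2)cc1` has not yet been measured. It keeps the core of compound 1 and makes one change, chloro in place of hydrogen on an aromatic carbon, para to a large group, which turns a phenyl into a 4-chlorophenyl: chloro in place of hydrogen on an aromatic carbon. Within the data shown here, no measured pair shows the effect of this change, so no direction can be favoured from the data, and no step beyond the scatter is expected in this assay. The estimate therefore starts from compound 1 at 56%. The expected step of a number 1 percentage points higher from compound 1 to compound 4 (within the scatter) is small. For compound 4 the estimated value is 57%, with an expected range from 35% to 78%.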

Compound 4, percent growth inhibition at one concentration: -25.8%
Compound 4: the middle estimate sits 82.8 percentage points above what was measured; measured number outside the range, below it.
By their numbers in this assay, from the lowest: compound 4; then compounds 2 and 3 (each within the scatter of the next); then compound 1.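

In this assay, adding one chloro para to a large group, which turns a phenyl into a 4-chlorophenyl, gives a number 81.8 percentage points lower from compound 1 to compound 4 (beyond the scatter), so this position on the core of compound 1 is highly sensitive to change. Compound 4 gives -25.8%, a negative number on this scale, so no inhibition of growth appears at the one concentration tested. Nothing measured here gives a reason for this step.

Fluoro, methyl or an amine at the same place would help show whether the loss is particular to chloro. They would also show whether other groups on this carbon give a similar loss. This single pair also leaves open whether the same change would act alike on a different core.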